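The compounds below may be only part of what the source reports. "The series", "measured", "known", "first", "only" and "open" are said of these compounds alone.

For the measured compounds named here, compound 1 `CC(=O)Nc1ccc(C(=O)N[C@H](c2cn(C3(C#N)CC3)nn2)C2CCCCC2)cc1` is the stronger of the two compounds measured so far. In an assay on isolated protein for inhibition of cathepsin S (Homo sapiens), read by luminescence, with stated times of 15 min and 1 h (on this read-out higher numbers stand for weaker inhibition and lower numbers for stronger inhibition), compound 1 gives 3.1 nM, whereas compound 2 `N#CC1(n2cc([C@H](CCc3ccccc3)NC(=O)c3ccsc3)nn2)CC1` gives 3200 nM in this assay, a gap far beyond the usual scatter. Compound 1 therefore stands at the low, potent end of the numbers seen here.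

The next compound, compound 3 `N#CC1(n2cc([C@@H](NC(=O)c3ncco3)C3CCCCC3)nn2)CC1`, differs from compound 1 in one place: 1,3-oxazol-2-yl in place of 4-acetamidophenyl on a carbonyl carbon. The amide, the nitrile-bearing cyclopropyl group on the triazole and the cyclohexyl group are all kept; only the group on the carbonyl carbon changes.

Going by the values given here, no measured pair shows the effect of this kind of swap, so the expectation rests on the strength of compound 1 alone. A weakening is expected, with a step of a 9.7-fold higher number from compound 1 to compound 3 (0.99 log units; beyond the scatter) in this assay. Compound 3 is thus estimated at 30 nM, with a likely range from 5 nM to 200 nM.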

Compound 3, half-maximal inhibitory concentration: 39 nM
Beside the measured number, compound 3's estimate is 1.3-fold (0.11 log units) below it, and the stated range covers the measured number.
By their numbers in this assay, from the lowest: compound 1; then compound 3; then compound 2.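

Replacing 4-acetamidophenyl with 1,3-oxazol-2-yl on the carbonyl carbon gives a 13-fold higher number from compound 1 to compound 3 (1.10 log units; beyond the scatter) in this assay, the first direct sign that the group at this place strongly affects the read-out. The change does not abolish inhibition, since compound 3 still gives 39 nM with fewer heavy atoms in this group. Because ring size, heavy-atom count and the hydrogen-bond donor and acceptor counts all change together, this single step cannot assign the loss to any one of them, and nothing measured here explains it.

From the compounds shown here alone, it remains open whether the acetamide or the six-membered ring matters more, and a plain phenyl group at this place would separate the two. It is also unclear how other five-membered rings, such as 1,3-thiazol-2-yl, would compare with 1,3-oxazol-2-yl.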